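Hydroxy in place of ethyl: an expected small step

A few compounds are considered here, and "the series" means these few. Any claim that something is new, unique, unknown or untested is made for them only; others in the source may bear on it.

Values measured in a functional assay on HBL-100 cells (Homo sapiens) for antiproliferative activity, read by sulforhodamine B assay, with a stated time of 48 h (on this read-out higher numbers stand for weaker inhibition of growth and lower numbers for stronger inhibition of growth), for two compounds:
- Compound 1 `CCCCCCCCCCCCCCC[C@@H](O)[C@@H](N)[C@@H](C)O` gives 21000 nM
- Compound 2 `CCCCCCCCC[C@@H](O)[C@@H](N)[C@@H](C)CC` gives 13000 nM

Compound 2 lies within the usual scatter of compound 1, so these two values cannot be ranked and neither compound counts as the stronger one.

The next compound to consider is compound 3 `CCCCCCCCC[C@@H](O)[C@@H](N)[C@@H](C)O` and its change from compound 2 is hydroxy in place of ethyl on a saturated chain carbon bound to two saturated chain carbons in one place. In words, this puts hydroxy in place of ethyl on a saturated chain carbon bound to two saturated chain carbons.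

Among the measured compounds shown here, no measured pair differs in only one place, so nothing yet shows how large such a swap tends to be in this assay and the expectation stays loose. For the measured compounds named here, the only guide is that compound 1 at 21000 nM and compound 2 at 13000 nM sit close together. A modest move toward a higher number, meaning weaker inhibition of growth, is expected, and it may not clear the scatter. The expected size is a 1.8-fold higher number from compound 2 to compound 3 (0.27 log units; within the scatter) on this estimate. For compound 3 the estimated value is 24000 nM with an expected range from 9000 nM to 65000 nM as the upper end.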

Compound 3, concentration for 50% growth inhibition: 13000 nM
Beside the measured number, compound 3's estimate is 1.8-fold (0.27 log units) above it; measured number inside the range.
By their numbers in this assay, from the lowest: compounds 2, 3 and 1 (each within the scatter of the next).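

In this assay, among the compounds shown here, hydroxy in place of ethyl on a saturated chain carbon bound to two saturated chain carbons gives no change at the digits printed from compound 2 to compound 3 (within the scatter) in the first one-place comparison at this position, so this swap, which brings in a hydrogen-bond donor and a hydrogen-bond acceptor, has no effect that this read-out can resolve. For the compounds shown here, compound 3 also gives the first one-place comparison for the long chain: hydrogen in place of hexyl on a saturated chain carbon gives a 1.6-fold lower number from compound 1 to compound 3 (0.21 log units; within the scatter) and so cannot be told apart from repeat-to-repeat variation either. No supporting measurement is available to explain either result.

On these data alone, with all three compounds lying within the scatter of their neighbours, it remains open whether an amine or a carboxylic acid in place of the hydroxy would shift the number beyond that scatter. Going by these compounds alone, it is equally open whether a chain longer than the one in compound 1 would do so.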